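Extending the carboxy chain from compound 2 to compound 3

This account rests on a few compounds, and the source may have more. Where it says the series, first, only, none or still open, it means among the compounds named here.

Measured in a functional assay on R2 cells (Cricetulus griseus) for inhibition, with R2 (Homo sapiens) as the target, read by CellTiter-Blue, with a stated time of 96 h; a higher number here means a weaker inhibitor, a lower number a stronger inhibitor:
- compound 1 `Nc1nc2[nH]c(CCCCCC(=O)O)cc2c(=O)[nH]1`: > 1000 nM (a limit)
- compound 2 `Nc1nc2[nH]c(CCCCCCC(=O)O)cc2c(=O)[nH]1`: > 1000 nM (a limit)

Among the measured compounds shown here, neither entry is a number, and the series so far offers no measured potency to build on. Compound 2 stands at the limit of > 1000 nM in this assay, at which 2 of the 2 values shown sit, so its position is known only as a limit.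

The compound still to be measured is compound 3 `Nc1nc2[nH]c(CCCCCCCC(=O)O)cc2c(=O)[nH]1`. It differs from compound 2 by carboxymethyl in place of carboxy on a saturated chain carbon, six bonds along the chain from an aromatic carbon.

For the measured compounds named here, only one measured step bears on this change. It is the same exchange made five bonds along the chain from an aromatic carbon, and it appears as a step that the two limits leave unreadable from compound 1 to compound 2. Going by the values given here, with that step as the only precedent, no size or direction can be carried over, and no shift beyond the scatter is expected. The assay will most likely report only a limit again.

The expected change is a step that the limit leaves unreadable from compound 2 to compound 3, which is an estimate only. Compound 3 is estimated at 2000 nM, with an expected range from 500 nM to 10000 nM.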

Compound 3, half-maximal inhibitory concentration: > 1000 nM
Compound 3: a limit, no number (the forecaster's own chance of this, stated with the estimate: 85%); the middle value is on the limit's open side.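

In this assay compound 3 gives > 1000 nM, which is a limit and not a number. No step can be read from compound 1 to compound 3 or from compound 2 to compound 3, because all three entries are limits: the limit of > 1000 nM in this assay, at which 3 of the 3 values shown sit.

The compounds shown leave open how compound 1, compound 2 and compound 3 rank, and whether any carboxy chain length gives a numerical potency.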